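Moving the Chlorine on the Phenyl Ring of Compound 2

The source may hold more compounds than are shown below. What is called first, only, known or untested is meant among the compounds shown, and "the series" means these compounds.

Compound 2, `O/N=C(\CCN1CCN(c2ccccn2)CC1)c1ccccc1Cl`, is one of three related molecules tested in a functional assay on HEK293 cells with D(4) dopamine receptor (Homo sapiens) as the target, read by FLIPR; a lower number here means a smaller maximal response, a higher number a larger maximal response. Compound 2 gives 74%. Compound 1, `O/N=C(/CCN1CCN(c2ccccn2)CC1)c1ccccc1`, gives 74%, level with compound 2 at the digits shown, and the two stand together as the highest of the three. Compound 3, `O/N=C(/CCN1CCN(c2ccccn2)CC1)c1ccccc1Cl`, gives 64%. The step of a number 10 percentage points lower from compound 1 to compound 3 (within the scatter) adds a chlorine to the phenyl ring; the step of a number 10 percentage points lower from compound 2 to compound 3 (within the scatter) changes only the drawn geometry of the double bond, because the fact that compounds 2 and 3 differ only in the configuration as drawn the two share every atom and bond. Both steps stay within the scatter, so neither the added chlorine nor the geometry moved the maximal response by an amount that can be trusted.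

Compound 4, `O/N=C(\CCN1CCN(c2ccccn2)CC1)c1cccc(Cl)c1`, has not yet been measured. It differs from compound 2 in one way: 3-chlorophenyl in place of 2-chlorophenyl on a carbon with a double bond to nitrogen. Among the compounds with values here, no measured step shows exactly this move, but the two steps that touch the chlorine or the geometry are each small. A change of no size beyond the scatter is therefore expected, a number 2 percentage points lower from compound 2 to compound 4 (within the scatter). Compound 4 is estimated at 72%, with a range from 55% to 86%.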

Compound 4, largest response reached (reported as efficacy), in percent of the reference or control that the assay uses: 73%
For compound 4 the middle estimate is 1 percentage points below the measured one, and the stated range covers the measured number.
By their numbers in this assay, from the lowest: compounds 3, 4, 1 and 2 (each within the scatter of the next).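

The earlier compounds shown here compared a chlorine with a hydrogen, and one double-bond geometry with the other, but always kept the chlorine in the same ring position. In this assay, 3-chlorophenyl in place of 2-chlorophenyl on a carbon with a double bond to nitrogen gives a number 1 percentage points lower from compound 2 to compound 4 (within the scatter), so this read-out does not separate the two chlorophenyl groups when the double bond keeps the geometry drawn in compound 2. Nothing given here bears on why these two groups read alike.

Still open, on these data alone, is whether a ring carrying methoxy or an amine in place of chlorine would give a similar maximal response. Within the data shown here, also open is how 3-chlorophenyl behaves with the opposite double-bond geometry, the one drawn in compound 3.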